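The source may hold more compounds than are shown below. What is called first, only, known or untested is meant among the compounds shown, and "the series" means these compounds.

Measured in a physicochemical assay for lipophilicity, at pH 7.4; a lower number here means a more polar compound, a higher number a more lipophilic compound:
- compound 1 `COc1ccc(NC(=O)[C@H]2CCCN2C(=O)C2(c3cccc(Cl)c3)CCCC2)nc1`: 6.8
- compound 2 `O=C(Nc1cnc2[nH]ncc2c1)[C@H]1CCCN1C(=O)C1(c2cccc(Cl)c2)CCCC1`: 4.9
- compound 3 `O=C(Nc1ccc2[nH]ncc2n1)[C@H]1CCCN1C(=O)C1(c2ccc(Cl)cc2)CC(F)(F)C1`: 4.7

Compound 2 lies within the usual scatter of compound 3 and well under compound 1. Compound 4 `CNC(=O)c1ccc(NC(=O)[C@H]2CCCN2C(=O)C2(c3cccc(Cl)c3)CCCC2)cc1` keeps the core of compound 2 but exchanges one group: a group of 10 heavy atoms (8 carbon, 1 nitrogen, 1 oxygen; one six-membered aromatic ring of carbon only) in place of a group of 9 heavy atoms (6 carbon, 3 nitrogen; one five-membered aromatic ring with 2 hetero atoms, one six-membered aromatic ring with 1 hetero atom), on an amide-type nitrogen. The entering group is 4-(methylcarbamoyl)phenyl. For the measured compounds named here, the one measured step at this place is a number 1.90 log units lower from compound 1 to compound 2 (beyond the scatter), large and beyond the scatter, so changes on this amide-type nitrogen can move this assay a long way. That step did not involve the entering group, so it sets no firm size or direction here. A modest upward move is expected, a number 0.40 log units higher from compound 2 to compound 4 (beyond the scatter). The estimate for compound 4 is 5.3, with an expected range of 4.7 to 6.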

Compound 4, distribution coefficient: 5.3
Estimate against measurement, compound 4: no gap at the digits printed; measured number inside the range.
By their numbers in this assay, from the lowest: compounds 3 and 2 (each within the scatter of the next); then compound 4; then compound 1.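

In this assay, a third kind of group on this amide-type nitrogen, 4-(methylcarbamoyl)phenyl with a ring of carbon only, again lies far from the 5-methoxypyridin-2-yl group (a number 1.50 log units lower from compound 1 to compound 4 (beyond the scatter)). Against the group of compound 2 the shift is much smaller (a number 0.40 log units higher from compound 2 to compound 4 (beyond the scatter)), so a large drop from compound 1 does not require the two-ring group of compound 2. Nothing available explains these differences. Open, as far as these compounds go, is how a carboxylic acid or an amine in place of the methylcarbamoyl group would read in this assay.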